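A few compounds are considered here, and "the series" means these few. Any claim that something is new, unique, unknown or untested is made for them only; others in the source may bear on it.

For the measured compounds named here, in a functional assay on MCF7 cells (Homo sapiens) for inhibition, read by CCK-8 assay, with a stated time of 48 h (on this read-out higher numbers stand for weaker inhibition and lower numbers for stronger inhibition), compound 3 `COc1cc(-c2ccnc3cc(-c4ccccc4)nn23)cc(OC)c1OC` gives 254 nM, the highest number of the three measured so far. Compound 2 `COc1cc(-c2ccnc3cc(-c4ccc(C)c(C)c4)nn23)cc(OC)c1OC` gives 26 nM, and compound 1 `COc1cc(-c2ccnc3cc(-c4cn(CO)c5ccccc45)nn23)cc(OC)c1OC` gives 19 nM. Compound 4 `COc1cc(-c2ccnc3cc(-c4cn(C)c5ccccc45)nn23)cc(OC)c1OC` has 1-methyl-1H-indol-3-yl in place of the phenyl of compound 3, on an aromatic carbon of the five-membered ring: 1-methyl-1H-indol-3-yl in place of phenyl on an aromatic carbon. Going by the values given here, the one measured step at this place is a 9.8-fold higher number from compound 2 to compound 3 (0.99 log units; beyond the scatter), a modest change beyond the scatter, in which losing the 3,4-dimethylphenyl raised the number. The closest measured relative of compound 4 is compound 1, which also lies far lower at 19 nM. A similar drop is therefore expected, and the expected change is a 10-fold lower number from compound 3 to compound 4 (1.01 log units; beyond the scatter). The estimate for compound 4 is 25 nM, with an expected range from 8 nM to 80 nM.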

Compound 4, half-maximal inhibitory concentration: 95 nM
Beside the measured number, compound 4's estimate is 3.8-fold (0.58 log units) below it; measured number outside the range, above it.
By their numbers in this assay, from the lowest: compounds 1 and 2 (each within the scatter of the next); then compound 4; then compound 3.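

In this assay the step to 1-methyl-1H-indol-3-yl on this aromatic carbon gives a 2.7-fold lower number from compound 3 to compound 4 (0.43 log units; beyond the scatter) and so improves on phenyl, yet the same group falls short of 3,4-dimethylphenyl, with a 3.7-fold higher number from compound 2 to compound 4 (0.56 log units; beyond the scatter) in that comparison. The result also shows that the substituent on the indole nitrogen counts: there is a 5.0-fold higher number from compound 1 to compound 4 (0.70 log units; beyond the scatter) when hydroxy gives way to hydrogen on the saturated chain carbon bound to the aromatic nitrogen. Nothing available explains these differences. Going by these compounds, it remains open whether an amine, a carboxylic acid or a longer chain on that aromatic nitrogen would keep the number as low as hydroxy does.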